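This account rests on a few compounds, and the source may have more. Where it says the series, first, only, none or still open, it means among the compounds named here.

Compound 1, `CS(=O)(=O)c1ccc(C(=O)NCC(=O)N(Cc2ccccc2)Cc2ccccc2)cc1[N+](=O)[O-]`: 11900 nM in an ADME assay on HepG2 cells (Homo sapiens) for cytotoxicity, read by CellTiter-Glo and ATP content, with a stated time of 72 h; a lower number here means that less compound is needed, a higher number that more compound is needed for the effect.
Compound 2, `CN1CCN(C(=O)CNC(=O)c2ccc(S(C)(=O)=O)c([N+](=O)[O-])c2)CC1`: > 27000 nM, which is a limit of this assay, not a number.
Compound 3, `CS(=O)(=O)c1ccc(C(=O)NCC(=O)N2CCc3ccccc3C2)cc1[N+](=O)[O-]`: > 27000 nM, likewise a limit.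

Compound 2 therefore stands at the upper edge of what this assay reports, and the limit of > 27000 nM in this assay, at which 2 of the 3 values shown sit, shows that it is not alone there. Compound 4, `CC(C)N(C(=O)CNC(=O)c1ccc(S(C)(=O)=O)c([N+](=O)[O-])c1)C(C)C`, differs from compound 2 in one place: diisopropylamino in place of 4-methylpiperazin-1-yl on a carbonyl carbon. Among the measured compounds shown here, no measured pair in this set carries that change, so the size of the step in this assay cannot be read from the data; the only number returned, that of compound 1, sits not far from the limit itself. Compound 4 is expected to stay near that limit, with a step of an at least 1.0-fold lower number from compound 2 to compound 4 (0.03 log units; that floor lies within the scatter) that is unlikely to exceed the usual scatter. Compound 4 is estimated at 25000 nM, with a range from 10000 nM to 60000 nM.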

Compound 4, half-maximal effective concentration: > 27000 nM
Compound 4: a limit, no number; the forecaster's own chance of this, stated with the estimate: 55%; at least 1.0-fold (0.03 log units) between middle value and limit.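

In this assay compound 4 gives > 27000 nM, a limit and not a number, as compound 2 also does, so no step can be read between the two. The compounds shown leave open how diisopropylamino and 4-methylpiperazin-1-yl compare in numbers.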